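Fluoro to bromo in a series stuck at its limit

The source may report more compounds than this note shows. Statements on the series, on what has been measured and on what is new or still open speak of the compounds shown alone.

Compound 1 `CCOC(=O)c1c(-c2cccc(Br)c2)[nH]c2cc(OC)c(Cl)cc2c1=O` gives > 21500 nM (a limit)
Compound 2 `CCOC(=O)c1c(-c2cccc(Oc3ccccc3)c2)[nH]c2cc(OC)c(F)cc2c1=O` gives > 21500 nM (a limit)
Compound 3 `CCOC(=O)c1c(-c2cccc(F)c2)[nH]c2cc(OC)c(F)cc2c1=O` gives > 21500 nM (a limit)

In an ADME assay on Raji cells (Homo sapiens) for cytotoxicity, read by luminescence, with a stated time of 72 h (on this read-out lower numbers stand for an effect already at smaller amounts and higher numbers for an effect only at larger amounts of compound), compound 3 stands at > 21500 nM as a limit, not a number. The whole set shows the limit of > 21500 nM in this assay, at which 3 of the 3 values shown sit, so no order among these compounds can be read. Compound 4 `CCOC(=O)c1c(-c2cccc(Br)c2)[nH]c2cc(OC)c(F)cc2c1=O` changes one group of compound 3: bromo in place of fluoro on an aromatic carbon that is, bromo in place of fluoro on an aromatic carbon, meta to a large group. Going by the values given here, the only measured step that bears on this is a step that the two limits leave unreadable from compound 2 to compound 3 and it offers no size to carry over. No change beyond the usual scatter is therefore expected in this assay and no direction is favoured. The expected move is a step that the limit leaves unreadable from compound 3 to compound 4 as an estimate only. Compound 4 is estimated at 25000 nM (15000 nM to 45000 nM).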

Compound 4, half-maximal effective concentration: > 21500 nM
Compound 4: only a limit was reported (the forecaster's own chance of this, stated with the estimate: 85%); the middle value lies beyond the limit too.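

Compound 4 joins compound 1, compound 2 and compound 3 with no readable step among them, because all four share one limit in this assay: the limit of > 21500 nM in this assay, at which 4 of the 4 values shown sit.

How far beyond that limit each of these compounds lies remains open.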